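The source may hold more compounds than are shown below. What is called first, only, known or untested is meant among the compounds shown, and "the series" means these compounds.

Measured compounds:
- compound 1, `CC(C)(N)CN(C(=O)[C@@H]1C[C@H]1c1ccccc1)c1ccc(-c2ccccc2)cc1`: 1.4 nM
- compound 2, `CC[C@H](C)[C@H](N)CN(C(=O)[C@@H]1C[C@H]1c1cccc(C)c1)c1ccc(-c2ccccc2)cc1`: 1200 nM
- compound 3, `CC(C)C[C@H](N)CN(C(=O)[C@@H]1C[C@H]1c1ccccc1)c1ccc(-c2ccncc2)cc1`: 13000 nM

Working notes. In a functional assay for agonist activity at G protein-coupled receptor 88 (Homo sapiens), read by HTRF and cAMP accumulation (a higher number here means that more compound is needed for the effect, a lower number that less compound is needed), compound 1 gives 1.4 nM and compound 2 gives 1200 nM. Compound 3 stands at the highest of the three numbers: in this assay compound 3 gives 13000 nM, beyond the scatter from compound 2 and far beyond the scatter from compound 1. For the measured compounds named here, compound 3 differs from both others in more than one place at once, so no single step between measured compounds is available to read off.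

Compound 4, `CC(C)C[C@H](N)CN(C(=O)[C@@H]1C[C@H]1c1ccccc1)c1ccc(C2=CCCCC2)cc1`, keeps the core and the amine side chain of compound 3 and changes only the distal ring: cyclohex-1-en-1-yl in place of pyridin-4-yl on an aromatic carbon. Going by the values given here, the only measured compound with a carbon-only ring in that position, compound 1, gives 1.4 nM in this assay, but it also carries a different side chain, so the comparison is confounded. Still, the step from compound 3 to compound 4 is expected to lower the number by a clear margin, and it is estimated as a 16-fold lower number from compound 3 to compound 4 (1.21 log units; beyond the scatter). For compound 4 the expected value in this assay is 800 nM, with a range from 100 nM to 5000 nM.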

Compound 4, half-maximal effective concentration: 1200 nM
Compound 4: the middle estimate sits 1.5-fold (0.18 log units) below what was measured; the range from low to high includes it.
By their numbers in this assay, from the lowest: compound 1; then compounds 2 and 4 (each within the scatter of the next); then compound 3.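

For the compounds shown here, the first single-place reading falls on the ring para to a large group: in this assay, cyclohex-1-en-1-yl in place of pyridin-4-yl gives an 11-fold lower number from compound 3 to compound 4 (1.03 log units; beyond the scatter), so this position clearly affects the read-out with the amine side chain and the rest of compound 3 held constant. The step exchanges a six-membered aromatic ring with one hetero atom and one hydrogen-bond acceptor for a six-membered non-aromatic ring of carbon only with no acceptor, so these differences change together and this pair cannot separate them. Nothing available explains the size of the step.

As far as these compounds go, it remains open how a fully saturated cyclohexyl ring or a pyridin-3-yl ring would read at this position, either of which would help separate loss of the ring nitrogen from loss of aromaticity. The contribution of the amine side chain also remains open, as no pair of compounds shown differs at that place alone, so the effect of the ring change on other side chains cannot be read.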